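The source may report more compounds than this note shows. Statements on the series, on what has been measured and on what is new or still open speak of the compounds shown alone.

Working notes on the series.

The first member is compound 1, `O=C(/C=C(/C=C/c1ccc(O)cc1)NCCCO)/C=C/c1ccc(O)cc1`. In a functional assay on Caco-2 cells (Homo sapiens) for activation, read by fluorescence, tested at 10 uM (on this read-out higher numbers stand for a weaker effect at the one concentration tested and lower numbers for a stronger effect), compound 1 gives 91.7%. Its partner with a shortened and capped side chain is compound 3, `COCCNC(=C\C(=O)/C=C/c1ccc(O)cc1)/C=C/c1ccc(O)cc1`, and in this assay compound 3 gives 89.7%. Within the data shown here, the single change between them is methoxy in place of hydroxymethyl on a saturated chain carbon, two bonds along the chain from an amine nitrogen, and it moves the read-out by a number 2 percentage points lower from compound 1 to compound 3 (within the scatter), so the two values stand together within the usual scatter and no ordering between compound 1 and compound 3 is claimed.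

A second pair starts from compound 2, `COc1cc(/C=C/C(=O)/C=C(/C=C/c2ccc(O)c(OC)c2)NCCCO)ccc1O`, which carries the unchanged hydroxypropyl chain on a different core. In this assay compound 2 gives 91%. The difference between the core of compound 1 and the core of compound 2 is not broken down here; the two values of compound 1 and compound 2 lie within the scatter of one another.

Not yet measured is compound 4, `COCCNC(=C\C(=O)/C=C/c1ccc(O)c(OC)c1)/C=C/c1ccc(O)c(OC)c1`. It relates to compound 2 exactly as compound 3 relates to compound 1: the change is methoxy in place of hydroxymethyl on a saturated chain carbon, two bonds along the chain from an amine nitrogen, at the same place as before. The step from compound 2 to compound 4 in this assay is expected to be a number 1.5 percentage points lower from compound 2 to compound 4 (within the scatter), because the same change gave a number 2 percentage points lower from compound 1 to compound 3 (within the scatter) on the other core and nothing in the series suggests that the core of compound 2 should respond differently. For compound 4 the value in this assay is therefore estimated at 89.5%, with a range from 83% to 95%.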

Compound 4, a percentage reported as activity, at one concentration (the size of the read-out at that concentration, not a potency): 75.6%
Beside the measured number, compound 4's estimate is 13.9 percentage points above it; the whole stated range lies above it.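

In this assay the exchange of (3-hydroxypropyl)amino for (2-methoxyethyl)amino on the core of compound 2 gives a number 15.4 percentage points lower from compound 2 to compound 4 (beyond the scatter), so on this core the change reads as a stronger effect at the one concentration tested. Set beside the earlier step, the two do not separate: the same change on two cores in this assay, a number 2 percentage points lower (within the scatter) from compound 1 to compound 3 and a number 15.4 percentage points lower (beyond the scatter) from compound 2 to compound 4, 13.4 percentage points apart, within the scatter of two such steps. The result therefore fits a change that carries from one core to the other, but it does not establish that the step keeps its size on both, nor that the core of compound 2 responds more strongly, as each core rests on a single pair read at a single concentration.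

Open, on these data alone, is which part of the change goes with the step on the core of compound 2, the capping of the oxygen or the shortening of the chain, a question that a 2-hydroxyethyl or a 3-methoxypropyl chain on the same nitrogen would address. Also open, as far as these compounds go, is how the read-out would respond to a chain ending in an amine or a carboxylic acid, and whether the change carries to any core beyond these two.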